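The source may hold more compounds than are shown below. What is called first, only, known or untested is meant among the compounds shown, and "the series" means these compounds.

Measured so far in a functional assay on NCI-H460 cells (Homo sapiens) for inhibition, read by sulforhodamine B assay, with a stated time of 48 h; on this read-out higher numbers stand for weaker inhibition of growth and lower numbers for stronger inhibition of growth:
Compound 1 `COC(=O)c1sc2cc(C#Cc3ccccn3)cnc2c1N` gives 34900 nM.
Compound 2 `COC(=O)c1sc2cc(C#Cc3ccccc3F)cnc2c1N` gives > 150000 nM, which is a limit of the assay and not a number.
Compound 3 `COC(=O)c1sc2cc(C#Cc3cccnc3)cnc2c1N` gives > 150000 nM, again a limit of the assay.

Compound 3 therefore stands at the limit of > 150000 nM in this assay, at which 2 of the 3 values shown sit; its activity is known only as weaker than that limit. Compound 4 `COC(=O)c1sc2cc(C#Cc3ccsc3)cnc2c1N` differs from it by thiophen-3-yl in place of pyridin-3-yl on a triple-bonded carbon. For the measured compounds named here, no measured step exchanges these two groups. The steps that reach compound 3 or its neighbours are an at least 4.2-fold higher number from compound 1 to compound 3 (0.63 log units; beyond the scatter) and an at least 4.2-fold higher number from compound 1 to compound 2 (0.63 log units; beyond the scatter), both moving away from pyridin-2-yl and both losing activity; between compound 2 and compound 3 there is a step that the two limits leave unreadable from compound 2 to compound 3. Neither step anchors the thiophen-3-yl change. In this assay compound 4 is expected to stay near the limit, with an at least 1.2-fold lower number from compound 3 to compound 4 (0.09 log units; that floor lies within the scatter). The estimate for compound 4 is 120000 nM, range 40000 nM to 300000 nM.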

Compound 4, concentration for 50% growth inhibition: 24800 nM
Beside the measured number, compound 4's estimate is 4.8-fold (0.68 log units) above it, outside the stated range (below it).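

In this assay, for the compounds shown here, pyridin-2-yl is not the only group on the triple-bonded carbon that gives a measurable value: thiophen-3-yl does too, with an at least 6.0-fold lower number from compound 3 to compound 4 (0.78 log units; beyond the scatter) and an at least 6.0-fold lower number from compound 2 to compound 4 (0.78 log units; beyond the scatter). Against pyridin-2-yl, thiophen-3-yl cannot be told apart here, with a 1.4-fold lower number from compound 1 to compound 4 (0.15 log units; within the scatter). Compound 2 and compound 3 remain limits of the assay, and the step between them cannot be read: the limit of > 150000 nM in this assay, at which 2 of the 4 values shown sit.

The compounds shown leave open whether thiophen-2-yl, plain phenyl or an aminomethyl group on the triple-bonded carbon would keep this activity. They also leave open what a carboxylic acid in place of the methyl ester would do.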